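Extending a methyl to propyl on a weak inhibitor

This account rests on a few compounds, and the source may have more. Where it says the series, first, only, none or still open, it means among the compounds named here.

Compound 1 `Cc1nc(C)n2c(Nc3cc[nH]n3)nccc12` and compound 2 `Cc1cnc(Nc2cc[nH]n2)n2c(C)nc(C)c12` differ by a methyl in place of hydrogen on an aromatic carbon. In a functional assay for inhibition, with Homo sapiens as the target (a higher number here means a weaker inhibitor, a lower number a stronger inhibitor), compound 1 gives 53000 nM. In this assay compound 2 gives only a limit of the assay, > 48000 nM. Because of the limit of > 48000 nM in this assay, at which 1 of the 2 values shown sits, the step that the limit leaves unreadable from compound 1 to compound 2 cannot be sized. Compound 3 `CCCc1nc(C)c2c(C)cnc(Nc3cc[nH]n3)n12` differs from compound 2 by ethyl in place of hydrogen on a saturated chain carbon bound to an aromatic carbon. Going by the values given here, no measured step alters a chain in this way, and the one step measured rests on a limit, so there is no sized step to build on. Compound 2 stands at a limit, and nothing among the numbers points toward a stronger inhibitor after this change. Compound 3 is therefore expected to remain a weak inhibitor, with an estimated step that the limit leaves unreadable from compound 2 to compound 3. The expected value for compound 3 in this assay is 60000 nM, with a range from 20000 nM to 200000 nM, and most likely only a limit will again be reported.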

Compound 3, half-maximal inhibitory concentration: > 48000 nM
Compound 3 gave a limit, no number; the forecaster's own chance of this, stated with the estimate: 70%; the middle value does not contradict the limit.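

Compound 2 and compound 3 both give only a limit of the assay in this assay, so no step between them can be read: the limit of > 48000 nM in this assay, at which 2 of the 3 values shown sit.

The compounds shown leave open how strongly compound 3 inhibits and whether extending methyl to propyl changes inhibition at all.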